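The source may hold more compounds than are shown below. What is called first, only, known or untested is meant among the compounds shown, and "the series" means these compounds.

The two measured compounds share a core and differ at two sites. Compound 1 `O=C(CN1CCN(c2nnc(Cc3ccccc3)c3ccccc23)CC1)Nc1c(F)cccc1F` carries a benzyl-bearing core and a 2,6-difluorophenyl amide; in a functional assay on A549 cells (Homo sapiens) for cytotoxicity, read by MTT assay, with a stated time of 72 h (on this read-out lower numbers stand for stronger inhibition and higher numbers for weaker inhibition), compound 1 gives 84500 nM. Compound 2 `O=C(CN1CCN(c2nnc(Cc3ccncc3)c3ccccc23)CC1)Nc1cccc(Br)c1` carries a pyridylmethyl-bearing core and a 3-bromophenyl amide; in this assay compound 2 gives 1530 nM. On these two numbers compound 2 stands lowest, and the distance to compound 1 lies well beyond the scatter of repeated measurements. The pair differs in two places. Nothing can be said about which of the two changes carries the difference.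

Compound 3 `O=C(CN1CCN(c2nnc(Cc3ccncc3)c3ccccc23)CC1)Nc1cc(C(F)(F)F)ccc1Cl` keeps everything of compound 2 except the aromatic group on the amide-type nitrogen, where the change is 2-chloro-5-(trifluoromethyl)phenyl in place of 3-bromophenyl on an amide-type nitrogen. Among the compounds with values here, no measured pair in the set isolates such a change, so there is no direct precedent. The step from compound 2 to compound 3 in this assay is expected to be small, a 1.6-fold higher number from compound 2 to compound 3 (0.21 log units; within the scatter), most likely within the scatter and with a slight lean toward a higher number. Compound 3 is therefore estimated at 2500 nM, with a plausible range from 600 nM to 12000 nM.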

Compound 3, half-maximal inhibitory concentration: 1850 nM
Compound 3: middle estimate off by 1.4-fold (0.13 log units), on the high side; the range from low to high includes it.
By their numbers in this assay, from the lowest: compounds 2 and 3 (each within the scatter of the next); then compound 1.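

In this assay the exchange of 3-bromophenyl for 2-chloro-5-(trifluoromethyl)phenyl on an amide-type nitrogen gives the only step shown that isolates this position, a 1.2-fold higher number from compound 2 to compound 3 (0.08 log units; within the scatter) and so the two compounds cannot be told apart on this read-out. With the pyridylmethyl-bearing core held fixed, the aromatic group on this nitrogen can therefore go from 7 to 11 heavy atoms, and from a bromine to a chlorine plus a trifluoromethyl group, with no change beyond the scatter. Nothing measured here gives a reason for this outcome, which stands as an observation on a single pair.

Within the data shown here, the wide gap between compound 1 and compound 2 still cannot be assigned to either site, since the benzyl and pyridylmethyl groups have not been compared with the amide aryl group held fixed, and the single step at the amide says nothing about 2,6-difluorophenyl. From the compounds shown here alone, it also remains open whether the same flat response would hold for a group of another kind on this nitrogen, such as cyclohexyl or a phenyl ring bearing a carboxylic acid or an amine.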